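Swapping fluoro for chloro on a growth inhibitor

A few compounds are considered here, and "the series" means these few. Any claim that something is new, unique, unknown or untested is made for them only; others in the source may bear on it.

- compound 1 `Cc1cc(C)c2c(O)cc(-c3ccc(Cl)cc3)nc2n1` gives 6310 nM
- compound 2 `Cc1ccnc2nc(-c3ccc(F)cc3)cc(O)c12` gives 51300 nM

In a functional assay on PC-3 cells (Homo sapiens) (a lower number here means a stronger inhibitor of growth, a higher number a weaker inhibitor of growth), compound 2 has the higher of the two numbers, which makes it the weaker inhibitor of this pair. Its gap to compound 1 lies beyond the usual scatter.

The next compound to consider is compound 3 `Cc1ccnc2nc(-c3ccc(Cl)cc3)cc(O)c12`, which has chloro in place of fluoro on an aromatic carbon. This carbon belongs to a six-membered aromatic ring of carbon only, para to a large group. Among the measured compounds shown here, no two measured compounds differ in one place alone, so no measured step shows what this swap does by itself. For the measured compounds named here, the only hint is compound 1 (6310 nM), which also carries chloro and has the lower number. That is thin evidence, so a moderate move toward a lower number in this assay is expected, and a result within the scatter of compound 2 would not be surprising. The expected change is a 2.9-fold lower number from compound 2 to compound 3 (0.45 log units; beyond the scatter) and it would mean a somewhat stronger inhibitor. For compound 3 the estimated value is 18000 nM (expected range 6000 nM to 50000 nM).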

Compound 3, concentration for 50% growth inhibition: 2880 nM
The estimate for compound 3 lay 6.3-fold (0.80 log units) above the measured number, and the stated range ends above it.
By their numbers in this assay, from the lowest: compound 3; then compound 1; then compound 2.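

In this assay, chloro in place of fluoro on an aromatic carbon, para to a large group, can now be read on its own, and it gives an 18-fold lower number from compound 2 to compound 3 (1.25 log units; beyond the scatter). This large step shows that growth inhibition in these cells is highly sensitive to which of these two halogens sits at this position, something the earlier pair could not show because compound 1 and compound 2 differ in more than one place. Compound 3 also allows a second comparison: hydrogen in place of methyl on an aromatic carbon gives a 2.2-fold lower number from compound 1 to compound 3 (0.34 log units; beyond the scatter), a modest step, so removing this methyl does not weaken inhibition in this pair, and no measurement shown here explains either step.

Whether bromo, methoxy or an amine at the para position would strengthen inhibition further remains open, since only chloro and fluoro are shown there. Among the compounds shown here, each change is also seen in only one pair, so it remains open whether chloro would give a step of similar size on the core of compound 1, which carries the extra methyl.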